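The source may report more compounds than this note shows. Statements on the series, on what has been measured and on what is new or still open speak of the compounds shown alone.

Compound 1 `CCCNC(=O)c1nc(-c2cccs2)[nH]c(=O)c1O` and compound 2 `O=C(NCCO)c1nc(-c2cccs2)[nH]c(=O)c1O` share one core and differ only in the amide substituent. In an assay on isolated protein for inhibition of Flap endonuclease 1 (Homo sapiens) (a lower number here means a stronger inhibitor, a higher number a weaker inhibitor), compound 1 gives 4200 nM, and in this assay compound 2 gives 4000 nM. Among the compounds with values here, the one step between them, a 1.1-fold lower number from compound 1 to compound 2 (0.02 log units; within the scatter), changes nothing beyond the scatter. Compound 2 thus holds the lowest of the two numbers, but its distance from compound 1 is within the scatter, so no order between the two can be claimed.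

Compound 3 `O=C(c1nc(-c2cccs2)[nH]c(=O)c1O)N1CCCC1` differs from compound 2 by pyrrolidin-1-yl in place of (2-hydroxyethyl)amino on a carbonyl carbon. The step from compound 1 to compound 2 bears on it only in part: it shows that exchanging the tail on the amide nitrogen left the number essentially unchanged, while the amide hydrogen itself was kept in both. Within the data shown here, for compound 3 the tail is closed into a ring and the amide hydrogen is gone, a change for which no measured step exists. Compound 3 is therefore expected to give about 5000 nM in this assay, between 2000 nM and 15000 nM, a change of a 1.3-fold higher number from compound 2 to compound 3 (0.10 log units; within the scatter) that is estimated to stay within the scatter.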

Compound 3, half-maximal inhibitory concentration: 13700 nM
Beside the measured number, compound 3's estimate is 2.7-fold (0.44 log units) below it, and the stated range covers the measured number.
By their numbers in this assay, from the lowest: compounds 2 and 1 (each within the scatter of the next); then compound 3.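

Unlike the earlier pair, where one open tail on the amide nitrogen replaced another, this change registers beyond the scatter in this assay and shows that the substituent on this carbonyl carbon does affect the number. Pyrrolidin-1-yl gives a 3.4-fold higher number from compound 2 to compound 3 (0.53 log units; beyond the scatter) and a 3.3-fold higher number from compound 1 to compound 3 (0.51 log units; beyond the scatter) so the direction is the same whichever open tail it replaces, and a hydroxy group on the tail is not needed to see the shift. Nothing shown explains this shift.

The change closes a ring and removes the amide hydrogen at once, and these compounds cannot separate the two. Diethylamino, which has no amide hydrogen and no ring, and cyclopentylamino, which keeps the amide hydrogen and carries a ring, would each address only one of them.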